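Swapping the cyclohexyl for a methoxyphenyl on the shared core

The source may report more compounds than this note shows. Statements on the series, on what has been measured and on what is new or still open speak of the compounds shown alone.

Of the compounds shown here, three with a shared core have been measured in a physicochemical assay for solubility, with a stated time of 18 h, at pH 7.4; on this read-out higher numbers stand for higher solubility and lower numbers for lower solubility. Compound 1 `COc1cccc(CNCCCNc2ccnc3cc(C4CCCCC4)ccc23)c1O` gives 4200 nM, and compound 2 `COc1ccc(F)cc1CNCCCNc1ccnc2cc(C3CCCCC3)ccc12` gives 4200 nM. The step of no change at the digits printed from compound 1 to compound 2 (within the scatter) shows that the change from one to the other left the read-out where it was. Compound 3 `c1ccc(Oc2ccc3c(NCCCNCc4ccco4)ccnc3c2)cc1`, which differs from the other two in several places, gives 14500 nM; its number stands above that of compound 2 by a gap that lies beyond the scatter, so compound 2 stands, together with compound 1, at the lowest point of the three.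

Compound 4 `COc1ccc(-c2ccc3c(NCCCNCc4cc(F)ccc4OC)ccnc3c2)cc1` has not yet been measured in this assay. Its change from compound 2 is 4-methoxyphenyl in place of cyclohexyl on an aromatic carbon.

Among the compounds with values here, none of the measured steps touches this position on the core: the only single-place step, from compound 1 to compound 2, alters the group on the chain carbon, not the group on the aromatic carbon. There is therefore no direct guide, and a step of modest size in either direction, or none beyond the scatter, is expected. The estimated step is a 1.1-fold higher number from compound 2 to compound 4 (0.03 log units; within the scatter). For compound 4 the expected value is 4500 nM, within a range from 1500 nM to 13000 nM.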

Compound 4, solubility: 32000 nM
For compound 4 the middle estimate is 7.1-fold (0.85 log units) below the measured one; measured number above the stated range.
By their numbers in this assay, from the lowest: compounds 1 and 2 (each within the scatter of the next); then compound 3; then compound 4.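

In this assay, the group on this aromatic carbon of the shared core proves able to move the read-out: 4-methoxyphenyl in place of cyclohexyl gives a 7.6-fold higher number from compound 2 to compound 4 (0.88 log units; beyond the scatter). Within the data shown here, the earlier compounds could not show this, since their only single-place step, at the group on the chain carbon, gave no change at the digits printed from compound 1 to compound 2 (within the scatter). No measurement shown here accounts for the size of the new step.

The swap makes two changes at once: a six-membered aromatic ring replaces a six-membered non-aromatic ring, and a methoxy group with its oxygen comes in, so the compounds shown cannot tell which of the two goes with the higher number; a plain phenyl at this carbon would separate them. From the compounds shown here alone, it also remains open whether the step would hold with the 2-hydroxy-3-methoxyphenyl of compound 1 on the chain carbon, and how quite different groups at this aromatic carbon, such as a piperidine or a carboxylic acid, would compare with cyclohexyl and 4-methoxyphenyl.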